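The source may report more compounds than this note shows. Statements on the series, on what has been measured and on what is new or still open speak of the compounds shown alone.

Measured in a functional assay on DU-145 cells (Homo sapiens) for cytotoxicity, read by MTT assay, with a stated time of 72 h; on this read-out lower numbers stand for an effect already at smaller amounts and higher numbers for an effect only at larger amounts of compound:
Compound 1, `CCc1cccc2c(OC)c(-c3occ(C)c3CBr)ccc12`, gives only a limit, > 10 ug/mL.
Compound 2, `CCc1cccc2c(OC)c(-c3occ(C)c3COCC(F)(F)F)ccc12`, gives 5.7 ug/mL.
Compound 3, `CCc1cccc2c(OC)c(-c3occ(C)c3COC(C)=O)ccc12`, gives only a limit, > 10 ug/mL.

Compound 3 thus stands at the limit of this assay, the limit at which two of the three values sit (the limit of > 10 ug/mL in this assay, at which 2 of the 3 values shown sit). Compound 4, `CCc1cccc2c(OC)c(-c3occ(C)c3COC(=O)CCN(CC)CC)ccc12`, differs from compound 3 by (diethylamino)methyl in place of hydrogen on a saturated chain carbon bound to a carbonyl carbon. Among the compounds with values here, no measured step touches that part of the molecule. The steps of an at least 1.7-fold lower number from compound 1 to compound 2 (0.24 log units; that floor lies within the scatter) and an at least 1.7-fold higher number from compound 2 to compound 3 (0.24 log units; that floor lies within the scatter) concern the group on the oxygen on the saturated carbon and show only how far compound 2 lies from the limit. The step that the two limits leave unreadable from compound 1 to compound 3 is unreadable. For compound 4 one therefore expects a number still near the limit, an expected step of an at least 1.2-fold lower number from compound 3 to compound 4 (0.09 log units; that floor lies within the scatter), estimated at 8 ug/mL, with a range from 3 ug/mL to 15 ug/mL.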

Compound 4, concentration for half-maximal effect: > 10 ug/mL
Compound 4 was reported as a limit; the forecaster's own chance of this, stated with the estimate: 50%; middle value at least 1.2-fold (0.09 log units) away from the limit.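

In this assay compound 4 gives > 10 ug/mL, which is a limit and not a number. So (diethylamino)methyl on a saturated chain carbon bound to a carbonyl carbon does not bring the acetoxy compound to a readable value, and the only readable comparison is an at least 1.7-fold higher number from compound 2 to compound 4 (0.24 log units; that floor lies within the scatter). The steps to compound 4 from compound 1 and compound 3 cannot be read because both ends of each are limits: the limit of > 10 ug/mL in this assay, at which 3 of the 4 values shown sit.

Going by these compounds, how far compound 1, compound 3 and compound 4 lie beyond that limit stays open. So does whether a morpholine or a carboxylic acid in place of the diethylamino group would give a readable value.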